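Swapping one group on the carbonyl carbon

The source may report more compounds than this note shows. Statements on the series, on what has been measured and on what is new or still open speak of the compounds shown alone.

Values in a physicochemical assay for solubility, at pH 7; a higher number here means a more soluble compound, a lower number a less soluble compound:
- Compound 1 `CN1CCC(C(=O)N2Cc3c(NC(=O)c4cc(F)cc(F)c4)n[nH]c3C2(C)C)CC1`: > 225000 nM (a limit, not a number)
- Compound 2 `CN1CCC(C(=O)N2Cc3c(NC(=O)c4cccs4)n[nH]c3C2(C)C)CC1`: 155000 nM
- Compound 3 `CN1CCC(C(=O)N2Cc3c(NC(=O)c4ccc(C(F)(F)F)cc4)n[nH]c3C2(C)C)CC1`: 191000 nM

In this assay compound 3 gives 191000 nM. Among the compounds with values here, the only other exact number belongs to compound 2, and the comparison reads a 1.2-fold higher number from compound 2 to compound 3 (0.09 log units; within the scatter), so these two cannot be told apart. Compound 1 stands at the limit of > 225000 nM in this assay, at which 1 of the 3 values shown sits.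

Compound 4 `CN1CCC(C(=O)N2Cc3c(NC(=O)c4cccc(F)c4)n[nH]c3C2(C)C)CC1` puts 3-fluorophenyl in place of 4-(trifluoromethyl)phenyl on a carbonyl carbon.

The other measured changes at this same place are small or only loosely bounded: an at least 1.4-fold lower number from compound 1 to compound 2 (0.16 log units; that floor lies within the scatter), and an at least 1.1-fold lower number from compound 1 to compound 3 (0.07 log units; that floor lies within the scatter). Both start from a limit, so they give floors and not true sizes. With so little movement among these three compounds, no step beyond the scatter is expected in this assay. The expected step is a 1.0-fold higher number from compound 3 to compound 4 (0.02 log units; within the scatter). For compound 4 the estimated value is 200000 nM, with an expected range of 140000 nM to 280000 nM.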

Compound 4, solubility: > 225000 nM
Compound 4 ended at the assay's limit; the forecaster's own chance of this, stated with the estimate: 35%; at least 1.1-fold (0.05 log units) between middle value and limit.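

In this assay, compound 4 gives a limit and not a number, and so does compound 1: the limit of > 225000 nM in this assay, at which 2 of the 4 values shown sit. The steps to compound 4 are therefore only floors, an at least 1.1-fold higher number from compound 3 to compound 4 (0.07 log units; that floor lies within the scatter) and an at least 1.4-fold higher number from compound 2 to compound 4 (0.16 log units; that floor lies within the scatter), so 3-fluorophenyl on this carbonyl carbon is not shown to differ from 4-(trifluoromethyl)phenyl or thiophen-2-yl. The step between compound 1 and compound 4, hydrogen in place of fluoro on an aromatic carbon, cannot be read, as both values are limits.

From the compounds shown here alone, the true values of compound 1 and compound 4 remain unknown, so any real difference between them stays hidden. Going by these compounds, it also remains open whether a group without an aromatic ring at this place, such as an amine, a carboxylic acid or a longer alkyl chain, would give a step beyond the scatter.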